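This account rests on a few compounds, and the source may have more. Where it says the series, first, only, none or still open, it means among the compounds named here.

In an assay on isolated protein for inhibition of protein deacetylase HDAC6 (Homo sapiens), read by fluorescence, with a stated time of 1 h, tested at 100 nM (on this read-out higher numbers stand for more inhibition at the one concentration tested (going by the name of the read-out) and lower numbers for less inhibition), compound 1 `Cc1cccc(CN2CCC(c3noc(CN(C)c4ncc(C(=O)NO)cn4)n3)CC2)c1` gives 54%. Compound 2 `CN(Cc1nc(C2CCN(Cc3ccc(F)cc3)CC2)no1)c1ncc(C(=O)NO)cn1` gives 65%. Compound 3 `CN(Cc1nc(C2CCN(Cc3ccc(F)cc3F)CC2)no1)c1ncc(C(=O)NO)cn1` gives 66%.

Compound 3 and compound 2 lie within the scatter of each other, their gap being a number 1 percentage points higher from compound 2 to compound 3 (within the scatter), and both stand clearly above compound 1, by a number 11 percentage points higher from compound 1 to compound 2 (beyond the scatter) and a number 12 percentage points higher from compound 1 to compound 3 (beyond the scatter). Compound 4 `CN(Cc1nc(C2CCN(Cc3ccc(F)cc3Cl)CC2)no1)c1ncc(C(=O)NO)cn1` differs from compound 3 by chloro in place of fluoro on an aromatic carbon. Going by the values given here, the one measured step that alters a single ring substituent, a number 1 percentage points higher from compound 2 to compound 3 (within the scatter), stayed within the scatter, and no measured step exchanges chloro for fluoro. The expected step is therefore small, no change at the digits printed from compound 3 to compound 4 (within the scatter), with no clear direction. Compound 4 is estimated at 66%, between 52% and 78%.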

Compound 4, a percentage reported as inhibition, at one concentration (the size of the read-out at that concentration, not a potency): 49%
Estimate against measurement, compound 4: 17 percentage points above; the measured number lies below the stated range.
By their numbers in this assay, from the lowest: compounds 4 and 1 (each within the scatter of the next); then compounds 2 and 3 (each within the scatter of the next).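

In this assay this aromatic carbon, ortho to a large group, proves sensitive to what it carries: chloro for fluoro gives a number 17 percentage points lower from compound 3 to compound 4 (beyond the scatter) and chloro for hydrogen gives a number 16 percentage points lower from compound 2 to compound 4 (beyond the scatter) at the same place. The earlier fluoro-for-hydrogen step alone gave no sign of this. The gain over the 3-methylphenyl compound also disappears, with a number 5 percentage points lower from compound 1 to compound 4 (within the scatter) in place of the clear steps seen for the two other benzyl groups. As far as these compounds go, whether a methyl or methoxy group here would follow chloro or fluoro stays open. Nothing available explains the drop.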